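A Pyridin-3-yl Swap on an Amine Nitrogen in a Ring

The source may report more compounds than this note shows. Statements on the series, on what has been measured and on what is new or still open speak of the compounds shown alone.

Of the compounds shown here, three have so far been measured in a functional assay on A-375 cells (Homo sapiens) for antiproliferative activity, read by CCK-8 assay, with a stated time of 72 h, tested at 2 uM; on this read-out lower numbers stand for a weaker effect and higher numbers for a stronger effect at the one concentration tested. Compound 1 `Nc1ccccc1NC(=O)c1ccc(CSC(=S)N2CCc3cc([N+](=O)[O-])ccc32)cc1` gives 16.9%, compound 2 `Nc1ccccc1NC(=O)c1ccc(CSC(=S)N2CCCc3ccccc32)cc1` gives 26.5%, and compound 3 `COc1ccc(N2CCN(C(=S)SCc3ccc(C(=O)Nc4ccccc4N)cc3)CC2)cc1` gives 28.1%. Compound 3 holds the highest of the three numbers; compound 2 lies within the scatter of it, while compound 1 sits beyond the scatter below it. Compound 4 `Nc1ccccc1NC(=O)c1ccc(CSC(=S)N2CCN(c3cccnc3)CC2)cc1` has not yet been measured. It differs from compound 3 in one place: pyridin-3-yl in place of 4-methoxyphenyl on an amine nitrogen in a ring. Among the compounds with values here, no step between two measured compounds is known, so the data give no guide to how this change moves the read-out. The step from compound 3 to compound 4 is therefore expected to be small, a number 3.1 percentage points lower from compound 3 to compound 4 (within the scatter), with no direction beyond the scatter. Compound 4 is expected to give 25%, between 12% and 38%.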

Compound 4, a percentage reported as inhibition, at one concentration (the size of the read-out at that concentration, not a potency): 40.5%
Compound 4: middle estimate off by 15.5 percentage points, on the low side; measured number above the stated range.
By their numbers in this assay, from the lowest: compounds 1, 2 and 3 (each within the scatter of the next, the first and the last beyond it); then compound 4.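

Read in this assay, pyridin-3-yl in place of 4-methoxyphenyl on an amine nitrogen in a ring gives a number 12.4 percentage points higher from compound 3 to compound 4 (beyond the scatter) and so provides the first step at this position. Within the data shown here, it shows that the read-out responds to the group carried on this nitrogen, which the earlier compounds, differing in more than one place, could not show. No measurement at hand accounts for the step.

The compounds shown leave open whether the gain goes with the nitrogen of the pyridin-3-yl ring or with the loss of the methoxy group. A plain phenyl or a pyridin-4-yl group at this place would help tell these apart.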